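Swapping the benzyl group on the side-chain amine

The source may report more compounds than this note shows. Statements on the series, on what has been measured and on what is new or still open speak of the compounds shown alone.

In a functional assay on SK-BR-3 cells (Homo sapiens) for antiproliferative activity (on this read-out higher numbers stand for weaker inhibition and lower numbers for stronger inhibition), compound 2 `CC(C)=CCc1cc(C(=O)Nc2cc3ccc(OCCCNCc4ccccc4)c(C)c3oc2=O)ccc1O` gives 470 nM and holds the lower of the two measured numbers, while compound 1 `CC(C)=CCc1cc(C(=O)Nc2cc3ccc(OCCCNCC(=O)O)c(C)c3oc2=O)ccc1O` gives 7570 nM on the same read-out. Compound 3 `CC(C)=CCc1cc(C(=O)Nc2cc3ccc(OCCCN[C@@H]4C[C@H]5CC[C@@H]4C5)c(C)c3oc2=O)ccc1O` departs from compound 2 in one place: a group of 7 heavy atoms (7 carbon; 2 five-membered non-aromatic rings of carbon only) in place of a group of 7 heavy atoms (7 carbon; one six-membered aromatic ring of carbon only), on an amine nitrogen is the whole change. For the measured compounds named here, the only measured step, a 16-fold lower number from compound 1 to compound 2 (1.21 log units; beyond the scatter) and large, put phenyl in place of carboxy, and no measured compound carries the new group. In this assay the expected step is therefore small: a 1.3-fold higher number from compound 2 to compound 3 (0.11 log units; within the scatter) is estimated and stays within the scatter, tilted towards a slightly higher number. The estimated value of compound 3 is 600 nM with a range of 200 nM to 1800 nM on this evidence.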

Compound 3, half-maximal inhibitory concentration: 770 nM
Estimate against measurement, compound 3: 1.3-fold (0.11 log units) below; measured number inside the range.
By their numbers in this assay, from the lowest: compounds 2 and 3 (each within the scatter of the next); then compound 1.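

In this assay, the group with 2 five-membered non-aromatic rings of carbon only replaces benzyl on the amine nitrogen with a 1.6-fold higher number from compound 2 to compound 3 (0.21 log units; within the scatter), so an aromatic ring is not needed here to keep the number of compound 2. Set against the carboxy-bearing side chain, the same group gives a 9.8-fold lower number from compound 1 to compound 3 (0.99 log units; beyond the scatter), so the earlier drop is not tied to phenyl alone. Nothing available explains why these two groups read alike.

Still open, on these data alone, is how a cyclohexyl or pyridylmethyl group would read on this amine nitrogen. A small methyl group there would show whether ring size matters at all.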